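A few compounds are considered here, and "the series" means these few. Any claim that something is new, unique, unknown or untested is made for them only; others in the source may bear on it.

Measured in a functional assay on MCF7 cells (Homo sapiens) for antiproliferative activity, read by MTT assay, with a stated time of 48 h; a lower number here means a stronger inhibitor, a higher number a weaker inhibitor:
- compound 1 `CCn1c(C(=O)NCCN(C)C)ccc1C(CC)(CC)c1ccc(OCCC(O)(CC)CC)c(C)c1`: 430 nM
- compound 2 `CCOC(=O)CN(C)C(=O)c1ccc(C(CC)(CC)c2ccc(OCCC(O)(CC)CC)c(C)c2)n1CC`: 3210 nM

Of these two, compound 2 carries the higher number, 3210 nM, and so is the weaker inhibitor. Compound 3 `CCn1c(C(=O)NC(C)C(=O)O)ccc1C(CC)(CC)c1ccc(OCCC(O)(CC)CC)c(C)c1` has not yet been measured. It differs from compound 2 by (1-carboxyethyl)amino in place of ((ethoxycarbonyl)methyl)(methyl)amino on a carbonyl carbon, with (1-carboxyethyl)amino in place of ((ethoxycarbonyl)methyl)(methyl)amino on a carbonyl carbon.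

Among the compounds with values here, only one measured step bears on this change: a 7.5-fold higher number from compound 1 to compound 2 (0.87 log units; beyond the scatter). That step brought in the group now leaving, in place of (2-(dimethylamino)ethyl)amino. Within the data shown here, compound 3 does not regain that group, and no measured compound carries (1-carboxyethyl)amino, so no recovery is assumed. In this assay, no step beyond the scatter is expected, though a slight rise is thought likelier than a fall. The expected change is a 1.2-fold higher number from compound 2 to compound 3 (0.10 log units; within the scatter). Compound 3 is estimated at 4000 nM, with an expected range of 1000 nM to 15000 nM.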

Compound 3, half-maximal inhibitory concentration: 19700 nM
For compound 3 the middle estimate is 4.9-fold (0.69 log units) below the measured one; measured number outside the range, above it.
By their numbers in this assay, from the lowest: compound 1; then compound 2; then compound 3.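

In this assay the group on this carbonyl carbon proved able to cost more than the earlier step had shown. (1-carboxyethyl)amino in place of ((ethoxycarbonyl)methyl)(methyl)amino still raised the number further (a 6.1-fold higher number from compound 2 to compound 3 (0.79 log units; beyond the scatter)), so the ((ethoxycarbonyl)methyl)(methyl)amino compound did not mark a floor for this position. With the shared core unchanged, 1-carboxyethyl in place of 2-(dimethylamino)ethyl on the amide-type nitrogen gave the widest gap in the set (a 46-fold higher number from compound 1 to compound 3 (1.66 log units; beyond the scatter)). Nothing given here accounts for these steps.

Compound 3 differs from compound 2 in several features of this group, so the compounds shown do not separate the carboxylic acid from the missing methyl on the nitrogen. Going by these compounds, how an ethyl ester of the same (1-carboxyethyl)amino group, or a longer chain ending in a dimethylamino group, would compare remains open.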